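Replacing diethylamino with piperidin-1-yl in compound 3

A few compounds are considered here, and "the series" means these few. Any claim that something is new, unique, unknown or untested is made for them only; others in the source may bear on it.

Of the compounds shown here, three sharing one core have been measured in a functional assay on HL60/MX2 cells (Homo sapiens) for antiproliferative activity, read by MTT assay, with a stated time of 48 h; on this read-out higher numbers stand for weaker inhibition and lower numbers for stronger inhibition. Compound 1 `CCN(CC)CCn1c(N)c(-c2nc3ccccc3[nH]2)c2nc(C#N)c(C#N)nc21` gives 7150 nM, and compound 2 `CN1CCN(CCn2c(N)c(-c3nc4ccccc4[nH]3)c3nc(C#N)c(C#N)nc32)CC1` gives 6490 nM. Compound 3 `CCN(CC)CCCn1c(N)c(-c2nc3ccccc3[nH]2)c2nc(C#N)c(C#N)nc21` gives 1820 nM, the lowest of the three numbers, which makes it the strongest inhibitor so far. Its lead is modest, as a 3.9-fold lower number from compound 1 to compound 3 (0.59 log units; beyond the scatter) and a 3.6-fold lower number from compound 2 to compound 3 (0.55 log units; beyond the scatter) show.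

The next compound, compound 4 `N#Cc1nc2c(-c3nc4ccccc4[nH]3)c(N)n(CCCN3CCCCC3)c2nc1C#N`, keeps the propyl chain of compound 3 and alters only the group carried on it: piperidin-1-yl in place of diethylamino on a saturated chain carbon, three bonds along the chain from an aromatic nitrogen. The nearest evidence is a 1.1-fold lower number from compound 1 to compound 2 (0.04 log units; within the scatter), in which 4-methylpiperazin-1-yl took the place of diethylamino, two bonds along the chain from an aromatic nitrogen. That swap to a ring-bearing group stayed within the scatter. For the measured compounds named here, it is only one pair, though, with a different ring and a different chain position, and no measured compound carries piperidin-1-yl. The larger step of a 3.9-fold lower number from compound 1 to compound 3 (0.59 log units; beyond the scatter) concerns the chain, which does not change here. No step beyond the scatter is therefore expected in this assay, and the estimated step is a 1.1-fold higher number from compound 3 to compound 4 (0.04 log units; within the scatter). The estimate for compound 4 is 2000 nM, with an expected range from 800 nM to 5000 nM.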

Compound 4, half-maximal inhibitory concentration: 1010 nM
Compound 4: the middle estimate sits 2.0-fold (0.30 log units) above what was measured; measured number inside the range.
By their numbers in this assay, from the lowest: compounds 4 and 3 (each within the scatter of the next); then compounds 2 and 1 (each within the scatter of the next).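

On the propyl chain, a ring can stand in for the open diethylamino group without a clear shift in this assay, since piperidin-1-yl in place of diethylamino gives a 1.8-fold lower number from compound 3 to compound 4 (0.26 log units; within the scatter). Compound 4 also differs from the two ethyl-chain compounds beyond the scatter, with a 6.4-fold lower number from compound 2 to compound 4 (0.81 log units; beyond the scatter) and a 7.1-fold lower number from compound 1 to compound 4 (0.85 log units; beyond the scatter), yet each of these steps changes the chain and the amine together, so neither can be credited to the ring alone; together with the step from compound 3, they suggest that among these four compounds the propyl chain matters more than the choice between these two end groups, though no evidence at hand explains why any of these numbers differ.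

From the compounds shown here alone, the effect of the ring on the shorter chain remains open, as 2-(piperidin-1-yl)ethyl would be needed to separate the ring from the chain length directly. Also open, going by these compounds, is whether the trend continues with a longer chain such as 4-(piperidin-1-yl)butyl, or holds for another ring such as morpholin-4-yl on the propyl chain.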